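Swapping the imidazole for a pyridine on the amine

The source may hold more compounds than are shown below. What is called first, only, known or untested is meant among the compounds shown, and "the series" means these compounds.

In a functional assay for antagonist activity at integrin alpha-5/beta-1 (Homo sapiens), read by ELISA (a higher number here means a weaker inhibitor, a lower number a stronger inhibitor), compound 3 `Cc1cc(C)c(S(=O)(=O)N[C@@H](CNC(=O)C2=NO[C@]3(C2)C[C@@H](CNc2ncc[nH]2)N(C(=O)OCc2ccccc2)C3)C(=O)O)c(C)c1` gives 18 nM, standing second highest of the three numbers: compound 1 `Cc1cc(C)c(S(=O)(=O)N[C@@H](CNC(=O)C2=NO[C@]3(CN[C@H](CNc4ncc[nH]4)C3)C2)C(=O)O)c(C)c1` gives 230 nM in this assay, while compound 2 `COC(=O)N1C[C@@]2(CC(C(=O)NC[C@H](NS(=O)(=O)c3c(C)cc(C)cc3C)C(=O)O)=NO2)C[C@H]1CNc1nc2ccccc2[nH]1` gives 1.4 nM. Among the measured compounds shown here, the only single-place step available is a 13-fold lower number from compound 1 to compound 3 (1.11 log units; beyond the scatter). Compound 4 `Cc1cc(C)c(S(=O)(=O)N[C@@H](CNC(=O)C2=NO[C@]3(C2)C[C@@H](CNc2ccccn2)N(C(=O)OCc2ccccc2)C3)C(=O)O)c(C)c1` differs from compound 3 by pyridin-2-yl in place of 1H-imidazol-2-yl on an amine nitrogen. For the measured compounds named here, no measured step touches this position, so nothing here sets the size directly; with one hydrogen-bond donor leaving the amine substituent, a modest weakening is expected, as a 3.3-fold higher number from compound 3 to compound 4 (0.52 log units; beyond the scatter). Compound 4 is therefore estimated at 60 nM in this assay, within a range from 15 nM to 300 nM.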

Compound 4, half-maximal inhibitory concentration: 0.18 nM
Estimate against measurement, compound 4: 330-fold (2.52 log units) above; the whole stated range lies above it.
By their numbers in this assay, from the lowest: compound 4; then compound 2; then compound 3; then compound 1.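

In this assay, the substituent on this amine nitrogen proves to be a position of large effect, with a 100-fold lower number from compound 3 to compound 4 (2.00 log units; beyond the scatter) on going from 1H-imidazol-2-yl to pyridin-2-yl. The group that enters has no hydrogen-bond donor, so in this pair a donor on the ring is not needed for the lower number. Nothing available accounts for the size of this step. The compounds shown leave open whether a pyrimidin-2-yl group here would keep the low number, and whether pyridin-2-yl gives a similar step with hydrogen in place of benzyloxycarbonyl on the ring nitrogen.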